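The compounds below may be only part of what the source reports. "The series", "measured", "known", "first", "only" and "open" are said of these compounds alone.

Measured compounds:
- compound 1, `O=c1cc(CSc2nc3ccccc3s2)oc2ccc(Cl)cc12`: a functional assay on HEp-2 cells (Homo sapiens) for cytotoxicity, read by MTT assay, with a stated time of 72 h (on this read-out higher numbers stand for weaker inhibition and lower numbers for stronger inhibition), reads > 25000 nM
- compound 2, `O=c1c(CSc2nc3ccccc3o2)coc2ccccc12`: in this assay compound 2 reads 2700 nM.

For compound 1 the figure in this assay is a limit of the assay, not a number: the value sits at the limit of > 25000 nM in this assay, at which 1 of the 2 values shown sits, so where compound 1 stands cannot be fixed more closely than that. Compound 2 gives a measured number, 2700 nM, in this assay. Compound 1 and compound 2 differ from each other in more than one place, so the two values are noted side by side without drawing a step between them.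

Compound 3, `Cc1ccc2oc(CSc3nc4ccccc4s3)cc(=O)c2c1`, differs from compound 1 by methyl in place of chloro on an aromatic carbon. Within the data shown here, no step between measured compounds is available to calibrate this change. With compound 1 sitting at a limit, the expected step that the limit leaves unreadable from compound 1 to compound 3 from compound 1 to compound 3 in this assay is none beyond the usual scatter, and the more likely outcome is that compound 3 also returns only a limit. The working estimate for compound 3 in this assay is 30000 nM, within a range of 8000 nM to 100000 nM.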

Compound 3, half-maximal inhibitory concentration: > 25000 nM
Compound 3: no number, only a limit (the forecaster's own chance of this, stated with the estimate: 60%); the middle value does not contradict the limit.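

In this assay compound 3 gives > 25000 nM, a limit of the assay and not a number. Compound 1 also gives only a limit, so no step between compound 1 and compound 3 can be read: the limit of > 25000 nM in this assay, at which 2 of the 3 values shown sit.

The compounds shown leave open what methyl in place of chloro on an aromatic carbon does to the value in this assay.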